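A few compounds are considered here, and "the series" means these few. Any claim that something is new, unique, unknown or untested is made for them only; others in the source may bear on it.

Within the data shown here, compound 1 `NC(=O)c1c(NC(=O)c2ccccc2Cl)sc2c1CCN(Cc1ccccc1F)C2` stands at the highest of the two numbers measured so far in a functional assay on MKN-74 cells (Homo sapiens) for antiproliferative activity, with a stated time of 24 h (on this read-out higher numbers stand for weaker inhibition and lower numbers for stronger inhibition), where compound 1 gives 12900 nM. Among the measured compounds shown here, its only neighbour is compound 2 `Cc1ccccc1NC(=S)N1CCc2c(sc(NC(=O)c3ccccc3Cl)c2C(N)=O)C1`, which in this assay gives 11700 nM; the step of a 1.1-fold lower number from compound 1 to compound 2 (0.04 log units; within the scatter) lies within the scatter, so the two compounds cannot be ranked against each other.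

Compound 3 `COc1ccc(NC(=S)N2CCc3c(sc(NC(=O)c4ccccc4Cl)c3C(N)=O)C2)cc1` has not yet been measured. It differs from compound 1 in one place: a group of 11 heavy atoms (8 carbon, 1 nitrogen, 1 oxygen, 1 sulfur; one six-membered aromatic ring of carbon only) in place of a group of 8 heavy atoms (7 carbon, 1 fluorine; one six-membered aromatic ring of carbon only), on an amine nitrogen in a ring. For the measured compounds named here, the one measured step that bears on this change is the one from compound 1 to compound 2, which also replaces the 2-fluorobenzyl on the amine nitrogen in a ring with a larger group containing nitrogen and sulfur, and that exchange left the number essentially unchanged. Nothing in the measured pair suggests that the group entering in compound 3 would move the number further. Compound 3 is therefore expected to give about 12000 nM, with a likely range from 5000 nM to 30000 nM, an expected step of a 1.1-fold lower number from compound 1 to compound 3 (0.03 log units; within the scatter) that points in no clear direction beyond the scatter.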

Compound 3, half-maximal inhibitory concentration: 19600 nM
Compound 3: middle estimate off by 1.6-fold (0.21 log units), on the low side, within the range that was stated.
By their numbers in this assay, from the lowest: compounds 2, 1 and 3 (each within the scatter of the next).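

Compound 3 shows that a second group of the larger sulfur-containing kind on the amine nitrogen in a ring also stays close to the 2-fluorobenzyl of compound 1 in this assay (a 1.5-fold higher number from compound 1 to compound 3 (0.18 log units; within the scatter)). It also gives the first direct comparison within this kind of group, since 4-methoxyphenyl in place of 2-methylphenyl on an amide-type nitrogen (a 1.7-fold higher number from compound 2 to compound 3 (0.22 log units; within the scatter)) likewise does not separate the two compounds. No measurement is available here that could explain these small steps.

Going by these compounds, all three compounds remain within the scatter of one another, so it stays open whether any group on this ring nitrogen can clearly shift the number. A plain hydrogen or a methyl there, or a carboxylic acid or an aliphatic amine on the aromatic ring of the entering group, would test this more sharply than another exchange between methyl and methoxy.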